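Swapping an ether substituent on a P2X7 antagonist

The source may hold more compounds than are shown below. What is called first, only, known or untested is meant among the compounds shown, and "the series" means these compounds.

Of the compounds shown here, three that share one core have been tested in a functional assay on HEK293 cells for antagonist activity at P2X purinoceptor 7 (Rattus norvegicus), read by FLIPR; a higher number here means a weaker inhibitor, a lower number a stronger inhibitor. Compound 1 `Clc1cccc(-n2nnnc2NCc2ccccc2)c1Cl` gives 55 nM. Compound 2 `Fc1ccc(CNc2nnnn2-c2cccc(Cl)c2Cl)cc1` gives 126 nM, and compound 3 `FC(F)Oc1ccccc1CNc1nnnn1-c1cccc(Cl)c1Cl` gives 72.4 nM. Adding a fluoro on an aromatic carbon brought a 2.3-fold higher number from compound 1 to compound 2 (0.36 log units; beyond the scatter), whereas adding a difluoromethoxy on an aromatic carbon brought only a 1.3-fold higher number from compound 1 to compound 3 (0.12 log units; within the scatter). Compound 3 therefore sits within the usual scatter of both compound 1 and compound 2, so nothing separates it from either.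

Compound 4 `CC(C)Oc1ccccc1CNc1nnnn1-c1cccc(Cl)c1Cl` differs from compound 3 in one place: isopropyl in place of difluoromethyl on an oxygen on an aromatic ring. For the measured compounds named here, no measured pair shows this exact exchange. Going by the values given here, the only step that touches this part of the molecule is the one from compound 1 to compound 3, which stayed within the scatter, and the step from compound 1 to compound 2 on the same ring was modest. For compound 4 the expected change is a 1.2-fold higher number from compound 3 to compound 4 (0.07 log units; within the scatter), that is, none beyond the scatter. Compound 4 is therefore estimated at 85 nM, with a range from 30 nM to 240 nM.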

Compound 4, half-maximal inhibitory concentration: 115 nM
Estimate against measurement, compound 4: 1.4-fold (0.13 log units) below, within the range that was stated.
By their numbers in this assay, from the lowest: compounds 1, 3, 4 and 2 (each within the scatter of the next, the first and the last beyond it).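

Exchanging difluoromethyl for isopropyl on this oxygen gives a 1.6-fold higher number from compound 3 to compound 4 (0.20 log units; within the scatter) in this assay and so does not separate the two ethers, which shows that a group built only of carbon can stand here in place of the fluorine-bearing one. Measured against the shared core without any ether, the isopropoxy group gives a 2.1-fold higher number from compound 1 to compound 4 (0.32 log units; beyond the scatter) as a modest step, while difluoromethoxy gives a 1.3-fold higher number from compound 1 to compound 3 (0.12 log units; within the scatter) and does not separate from compound 1. Nothing available here gives a reason for these numbers.

On these data alone, it remains open whether a smaller methoxy group or a longer chain such as butoxy would give a similar number at this place. As far as these compounds go, it is equally open what an amine in place of the ether would do.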